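A few compounds are considered here, and "the series" means these few. Any claim that something is new, unique, unknown or untested is made for them only; others in the source may bear on it.

Measured compounds:
- compound 1 `NC(=O)CN(CCC(c1ccccc1)c1ccccc1)C(=O)CN(CCC(c1ccccc1)c1ccccc1)C(=O)CNCC1CCCO1`: 2720 nM
- compound 2 `O=C1CN(CC2CCCO2)C(=O)CN1CCC(c1ccccc1)c1ccccc1`: "not determined" (no result reported)
- compound 3 `NC(=O)CN(CC1CCCO1)C(=O)CNCCC(c1ccccc1)c1ccccc1`: "not determined" (no result reported)

Going by the values given here, in an ADME assay on MDA-MB-231 cells (Homo sapiens) for cytotoxicity, with a stated time of 72 h (a higher number here means a weaker inhibitor of growth, a lower number a stronger inhibitor of growth), compound 1 gives 2720 nM; it is the only compound of this set with a number, since compound 2 and compound 3 carry no result there. Compound 4 `O=C(CN(CCC(c1ccccc1)c1ccccc1)C(=O)CNCC1CCCO1)NCCC(c1ccccc1)c1ccccc1` is not yet measured. Its difference from compound 1 is hydrogen in place of carbamoylmethyl on an amide-type nitrogen, in words a hydrogen in place of carbamoylmethyl on an amide-type nitrogen. Among the compounds with values here, no step between two measured compounds is available to weigh this change, so the expectation rests on compound 1 alone: a step from compound 1 to compound 4 that stays within the usual scatter, with no preferred direction. Compound 4 is estimated at 3500 nM, range 1400 nM to 9000 nM, which means a step of a 1.3-fold higher number from compound 1 to compound 4 (0.11 log units; within the scatter).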

Compound 4, concentration for 50% growth inhibition: 1060 nM
The estimate for compound 4 lay 3.3-fold (0.52 log units) above the measured number; the measured number lies below the stated range.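

At this amide-type nitrogen, whose other neighbours are a carbonyl carbon and a saturated chain carbon, carbamoylmethyl is not required for growth inhibition in this assay: hydrogen in its place gives a 2.6-fold lower number from compound 1 to compound 4 (0.41 log units; beyond the scatter). Going by these compounds alone, this is the only readable step, so the finding rests on a single pair of compounds. Nothing measured here bears on the cause of this step. On these data alone, whether a methyl group, a longer chain, an amine or a carboxylic acid on this nitrogen would shift the number further remains open.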